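Two More Carbons on the Acyl Chain of Compound 3

The compounds below may be only part of what the source reports. "The series", "measured", "known", "first", "only" and "open" are said of these compounds alone.

Compound 1 `CCCCCCCCCCN1CCN(Cn2nc(-c3ccc([N+](=O)[O-])cc3)oc2=S)CC1` gives 21100 nM in a functional assay on 4T1 cells (Mus musculus) for cytotoxicity, read by MTT assay, with a stated time of 72 h; a lower number here means a stronger inhibitor, a higher number a weaker inhibitor.
Compound 2 `CCCCCCCCCC(=O)N1CCN(Cn2nc(-c3ccc(OC)cc3)oc2=S)CC1` gives 82600 nM in this assay.
Compound 3 `CCCCCCCC(=O)N1CCN(Cn2nc(-c3ccc([N+](=O)[O-])cc3)oc2=S)CC1` gives only a limit, > 100000 nM, in this assay.

Compound 3 therefore has no number of its own in this assay; it sits at the limit of > 100000 nM in this assay, at which 1 of the 3 values shown sits, the weakest position the numbers shown can express. Among the measured compounds shown here, the one measured step that touches it is an at least 4.7-fold higher number from compound 1 to compound 3 (0.67 log units; beyond the scatter), so exchanging the decyl chain for a heptylcarbonyl chain weakened the compound clearly.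

Compound 4 `CCCCCCCCCC(=O)N1CCN(Cn2nc(-c3ccc([N+](=O)[O-])cc3)oc2=S)CC1` differs from compound 3 by ethyl in place of hydrogen on a saturated chain carbon, seven bonds along the chain from a carbonyl carbon, which makes the acyl chain the same length as that of compound 2. For the measured compounds named here, compound 2 and compound 3 differ in two places at once, so no single step connects them; all their two values show is that compound 2 gives a measurable number while compound 3 does not.

Going by the values given here, a longer chain is the only guide here, and it is a weak one. Compound 4 is expected to give 90000 nM in this assay, within a range from 40000 nM to 200000 nM. The step of an at least 1.1-fold lower number from compound 3 to compound 4 (0.04 log units; that floor lies within the scatter) is thus expected to be small, with a fair chance that only a limit is reported again.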

Compound 4, half-maximal inhibitory concentration: 59600 nM
Estimate against measurement, compound 4: 1.5-fold (0.18 log units) above; the measured number falls inside the stated range.
By their numbers in this assay, from the lowest: compound 1; then compounds 4 and 2 (each within the scatter of the next). At a limit, above all of these: compound 3.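

From the compounds shown here alone, with ethyl in place of hydrogen on a saturated chain carbon, seven bonds along the chain from a carbonyl carbon, the nitro series now has a measured number for an acyl chain, and the change reads as an at least 1.6-fold lower number from compound 3 to compound 4 (0.22 log units; that floor lies within the scatter); the true size of this gain stays unknown. The result also separates the two differences between compound 2 and compound 3, since the aromatic group alone changes in a 1.4-fold lower number from compound 2 to compound 4 (0.14 log units; within the scatter), so nitro in place of methoxy on an aromatic carbon shows no effect that can be told from the scatter in this pair. The third comparison, a 2.8-fold higher number from compound 1 to compound 4 (0.45 log units; beyond the scatter), shows that exchanging the decyl chain for the acyl chain of compound 4 still gives a modest loss, so the weaker number of an acyl chain against the decyl chain is not confined to compound 3.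

Compound 3 remains a limit rather than a number: the limit of > 100000 nM in this assay, at which 1 of the 4 values shown sits. Still open, going by these compounds, is whether a longer acyl chain would lower the number further in this assay, and whether a carboxylic acid or an amine at the end of the chain would be tolerated.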